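Ethoxycarbonyl for isopropyl on a coumarin-amide series

The source may report more compounds than this note shows. Statements on the series, on what has been measured and on what is new or still open speak of the compounds shown alone.

Compound 2 `CC(C)c1ccc(NC(=O)c2cc3ccccc3oc2=O)cc1` is one of two measured members of this set. In an in vitro assay on BTI-TN-5B1-4 cells for inhibition of Amine oxidase [flavin-containing] A (Homo sapiens), read by fluorescence (on this read-out lower numbers stand for stronger inhibition and higher numbers for weaker inhibition), compound 2 gives 15100 nM, and compound 1 `CCc1ccc(NC(=O)c2cc3ccccc3oc2=O)cc1` gives 15700 nM; the step of a 1.0-fold lower number from compound 1 to compound 2 (0.02 log units; within the scatter) is within the scatter, so the two numbers stand side by side with no order between them. Compound 3 `CCOC(=O)c1ccc(NC(=O)c2cc3ccccc3oc2=O)cc1` carries the change (ethoxycarbonyl in place of isopropyl on an aromatic carbon). For the measured compounds named here, the only measured step, from compound 1 to compound 2, concerns a methyl added on a saturated chain carbon and therefore says nothing direct about replacing isopropyl with ethoxycarbonyl, which brings in two hydrogen-bond acceptors and a double bond outside aromatic rings. Going by the values given here, with no step to lean on, the expectation for compound 3 is a step of a 1.0-fold lower number from compound 2 to compound 3 (0.00 log units; within the scatter) that does not go beyond the scatter. Compound 3 is therefore estimated at 15000 nM, with a range from 5000 nM to 45000 nM.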

Compound 3, half-maximal inhibitory concentration: 16000 nM
Estimate against measurement, compound 3: 1.1-fold (0.03 log units) below; the measured number falls inside the stated range.
By their numbers in this assay, from the lowest: compounds 2, 1 and 3 (each within the scatter of the next).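

In this assay, the exchange at this place, on an aromatic carbon para to a large group, gives a 1.1-fold higher number from compound 2 to compound 3 (0.03 log units; within the scatter) and a 1.0-fold higher number from compound 1 to compound 3 (0.01 log units; within the scatter). Until now the series had shown only a methyl added on the saturated chain, whereas compound 3 shows that an ethoxycarbonyl, with its hydrogen-bond acceptors and its double bond outside aromatic rings, can stand here in place of isopropyl or ethyl with no step beyond the scatter. Nothing available accounts for how closely these numbers agree.

From the compounds shown here alone, all three compounds lie within the scatter of one another, so it remains open whether any group at this place can shift the number beyond it. A carboxylic acid, an amine or a longer chain there would be the next groups to compare.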